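Swapping the Aryl Group on Compound 2

A few compounds are considered here, and "the series" means these few. Any claim that something is new, unique, unknown or untested is made for them only; others in the source may bear on it.

Measured in a functional assay on A549 cells (Homo sapiens) for antiproliferative activity, read by MTT assay, with a stated time of 72 h; a lower number here means a stronger inhibitor, a higher number a weaker inhibitor:
Compound 1 `NC1=NC2(CCSCC2)N(OCCCOc2cccc(Cl)c2)C(N)=N1`: 60 nM
Compound 2 `NC1=NC2(CCOCC2)N(OCCCOc2ccc(Cl)cc2)C(N)=N1`: 360 nM

Of these two, compound 2 has the higher number, 360 nM, and so is the weaker inhibitor. The gap down to compound 1, at 60 nM, lies beyond the usual scatter, but the two compounds differ in more than one place, so it cannot be pinned on a single change.

Compound 3 `Cc1cc(C)cc(OCCCON2C(N)=NC(N)=NC23CCOCC3)c1` has not yet been measured. It carries 3,5-dimethylphenyl in place of 4-chlorophenyl on an oxygen on a saturated carbon.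

Among the compounds with values here, no measured pair shows the effect of this swap. Starting from compound 2 at 360 nM, no step beyond the scatter is expected in this assay, in either direction.

The expected change is a 1.2-fold lower number from compound 2 to compound 3 (0.08 log units; within the scatter).

For compound 3 the estimated value is 300 nM, with an expected range from 90 nM to 1000 nM.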

Compound 3, half-maximal inhibitory concentration: 710 nM
The estimate for compound 3 lay 2.4-fold (0.37 log units) below the measured number, within the range that was stated.
By their numbers in this assay, from the lowest: compound 1; then compounds 2 and 3 (each within the scatter of the next).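

In this assay, within the data shown here, the swap of 4-chlorophenyl for 3,5-dimethylphenyl on an oxygen on a saturated carbon gives a 2.0-fold higher number from compound 2 to compound 3 (0.29 log units; within the scatter) and this is the first direct reading of a change at this position. With the rest of the molecule held fixed, the two aryl groups cannot be told apart in this assay, even though one carries a chlorine and the other two methyl groups. Nothing in the data offers an explanation for this result.

Going by these compounds, a single pair says little about the position as a whole, so it remains open how a plain phenyl ring, a pyridine ring or an aryl ring carrying an amine or a carboxylic acid would behave here. On these data alone, it is also open whether a longer chain leading to the aryl group would shift the number.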